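The compounds below may be only part of what the source reports. "The series", "measured", "known", "first", "only" and "open" are said of these compounds alone.

Measured compounds:
- Compound 1, `NC[C@@H]1CCCc2cc(S(=O)(=O)Cc3ccccc3)ccc21`: in an assay on isolated protein for displacement of a labelled ligand from 5-hydroxytryptamine receptor 6 (Homo sapiens) (on this read-out higher numbers stand for weaker inhibition and lower numbers for stronger inhibition), compound 1 gives 158 nM.
- Compound 2, `O=S(=O)(c1cccc(F)c1)c1ccc2c(c1)CCC[C@H]2CN1CC(O)C1`: in this assay compound 2 gives 0.1 nM.

Compound 2 stands at the lowest of the two numbers; the nearest is compound 1, whose value is far higher, a gap well beyond the usual scatter. The pair differs in more than one place, so the two values are simply compared as they stand.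

The step to compound 3, `CC(=O)N(C)C[C@@H]1CCCc2cc(S(=O)(=O)c3cccc(F)c3)ccc21`, changes the group on a saturated chain carbon bound to a saturated ring carbon: acetyl(methyl)amino in place of 3-hydroxyazetidin-1-yl on a saturated chain carbon bound to a saturated ring carbon. Among the compounds with values here, no measured pair shows a change of this kind, so its effect rests on expectation alone. For compound 3 a substantial rise in the number, beyond the scatter, is expected, as a 500-fold higher number from compound 2 to compound 3 (2.70 log units; beyond the scatter). Compound 3 is therefore estimated at 50 nM, with a plausible range from 5 nM to 500 nM.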

Compound 3, inhibition constant: 1.59 nM
Beside the measured number, compound 3's estimate is 31-fold (1.50 log units) above it; measured number below the stated range.
By their numbers in this assay, from the lowest: compound 2; then compound 3; then compound 1.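

Placing acetyl(methyl)amino in place of 3-hydroxyazetidin-1-yl on a saturated chain carbon bound to a saturated ring carbon gives a 16-fold higher number from compound 2 to compound 3 (1.20 log units; beyond the scatter) in this assay, the first reading of a change at this position alone. The two groups have the same count of heavy atoms, so a large step beyond the scatter arises here without any change in that count, and compound 3 still gives 1.59 nM. This single step cannot separate the loss of the ring from the loss of the hydrogen-bond donor, and no supporting data explain its size.

Going by these compounds, it remains open where a plain azetidin-1-yl group or a dimethylamino group would fall at this position. On these data alone, whether a hydroxyl on an open chain there would behave like the 3-hydroxyazetidin-1-yl group also remains open.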